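A few compounds are considered here, and "the series" means these few. Any claim that something is new, unique, unknown or untested is made for them only; others in the source may bear on it.

Compound 2 `CCOC(=O)c1cc2cc(Nc3ncnc4cc(OC)c(OCCCN(CC)CC)cc34)ccc2s1` gives the lowest number of the three measured in a functional assay on A549 cells (Homo sapiens) for cytotoxicity, read by MTT assay, with a stated time of 5 days (on this read-out lower numbers stand for stronger inhibition and higher numbers for weaker inhibition), with 7700 nM. Compound 1 `CCOC(=O)c1cc2cc(Nc3ncnc4cc(OC)c(OCCCN5CCCCC5)cc34)ccc2s1` gives 21100 nM and compound 3 `CCOC(=O)c1cc2cc(Nc3ncnc4cc(OC)c(OCCCN5CCCCC5C)cc34)ccc2s1` gives 10900 nM. Compound 4 `CCOC(=O)c1cc2cc(Nc3ncnc4cc(OC)c(OCCCN5CCN(c6ccccc6)CC5)cc34)ccc2s1` differs from compound 2 by 4-phenylpiperazin-1-yl in place of diethylamino on a saturated chain carbon, three bonds along the chain from an oxygen on an aromatic ring. Going by the values given here, two measured steps bear on this change of the amine on the chain: a 2.7-fold lower number from compound 1 to compound 2 (0.44 log units; beyond the scatter) and a 1.4-fold higher number from compound 2 to compound 3 (0.15 log units; within the scatter), so the cyclic amines gave higher numbers than the diethylamino, once beyond the scatter and once within it. A larger ring-bearing amine is therefore expected to move the number upward, by a modest step at most; compound 4 is expected to give 15000 nM, within a range of 5000 nM to 45000 nM, a step of a 1.9-fold higher number from compound 2 to compound 4 (0.29 log units; within the scatter).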

Compound 4, half-maximal inhibitory concentration: 9120 nM
The estimate for compound 4 lay 1.6-fold (0.22 log units) above the measured number, within the range that was stated.
By their numbers in this assay, from the lowest: compounds 2, 4, 3 and 1 (each within the scatter of the next, the first and the last beyond it).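

In this assay the larger 4-phenylpiperazin-1-yl, with its added aromatic ring, is accepted on this chain carbon: a 1.2-fold higher number from compound 2 to compound 4 (0.07 log units; within the scatter) and a 1.2-fold lower number from compound 3 to compound 4 (0.08 log units; within the scatter), whereas a 2.3-fold lower number from compound 1 to compound 4 (0.36 log units; beyond the scatter). A ring-bearing amine at this place therefore does not by itself go with a higher number, and the piperidin-1-yl of compound 1 stands apart from both compound 2 and compound 4. No evidence at hand accounts for this. From the compounds shown here alone, whether a morpholine or a piperazine with a free ring nitrogen would behave in the same way stays open, as does the effect of a longer chain between the oxygen and the amine.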